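The compounds below may be only part of what the source reports. "The series", "measured", "known", "first", "only" and "open" are said of these compounds alone.

In an ADME assay on BHK cells (Mesocricetus auratus) for cytotoxicity, read by MTT assay, with a stated time of 96 h (a higher number here means that more compound is tolerated, a lower number that less compound is tolerated), the measured compounds read as follows.

- Compound 1 `CCNC(=S)Nc1cccc(C(F)(F)F)c1` gives > 100000 nM as a limit of the assay, not a number
- Compound 2 `Fc1ccc(NC(=S)Nc2cccc(C(F)(F)F)c2)cc1` gives 26000 nM
- Compound 3 `FC(F)(F)c1cccc(NC(=S)Nc2cccc(Br)c2)c1` gives 10000 nM

Compound 3 stands lowest of the two actual numbers, and a 2.6-fold lower number from compound 2 to compound 3 (0.41 log units; beyond the scatter) separates it from its nearest neighbour. Compound 4 `C=C(C)CNC(=S)Nc1cccc(C(F)(F)F)c1` carries 2-methylprop-2-en-1-yl in place of 3-bromophenyl on an amide-type nitrogen and so has no ring at that place. The closest guide is the pair of steps away from the ethyl of compound 1, an at least 3.8-fold lower number from compound 1 to compound 2 (0.58 log units; beyond the scatter) and an at least 10-fold lower number from compound 1 to compound 3 (1.00 log units; beyond the scatter). Both lowered the number in this assay when a phenyl group replaced ethyl, and the larger of them led to compound 3. Read in reverse, they suggest that removing the ring should raise the number well beyond the scatter, although the new chain is not ethyl and some of that gain may not return. The expected step is a 7.0-fold higher number from compound 3 to compound 4 (0.85 log units; beyond the scatter) and the assay limit may be reached again. Compound 4 is estimated at 70000 nM in this assay. The expected range for compound 4 runs from 25000 nM to 150000 nM and the measurement itself remains to be seen.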

Compound 4, half-maximal cytotoxic concentration: > 100000 nM
Compound 4: no number, only a limit; the forecaster's own chance of this, stated with the estimate: 50%; middle value at least 1.4-fold (0.15 log units) from the limit.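

In this assay compound 4 gives > 100000 nM, which is a limit of the assay and not a number. Putting the open 2-methylprop-2-en-1-yl chain in place of a ring on the amide-type nitrogen gives an at least 10-fold higher number from compound 3 to compound 4 (1.00 log units; beyond the scatter) and an at least 3.8-fold higher number from compound 2 to compound 4 (0.58 log units; beyond the scatter), so a chain other than ethyl, one carrying a double bond, also sits clear of both ring compounds, and none of the compounds shown goes against this. The step between compound 1 and compound 4 cannot be read, and the two chains cannot be ordered: the limit of > 100000 nM in this assay, at which 2 of the 4 values shown sit.

On these data alone, whether the lower numbers belong to any ring at this place or only to an aromatic one stays open, and a cyclohexyl group on the same nitrogen would bear on that. As far as these compounds go, how a chain ending in an amine would read in this assay also stays open.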